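From nitro to methanesulfonamido: will cells still tolerate it?

A few compounds are considered here, and "the series" means these few. Any claim that something is new, unique, unknown or untested is made for them only; others in the source may bear on it.

In an ADME assay on HEK293 cells (Homo sapiens) for cytotoxicity, read by MTT assay, with a stated time of 48 h (a higher number here means that more compound is tolerated, a lower number that less compound is tolerated), compound 2 `Cc1ccc(N2C(=O)[C@H](CCCNS(=O)(=O)c3ccc(OC(F)(F)F)cc3)[C@H]2c2ccc([N+](=O)[O-])cc2)cc1` gives > 100000 nM, which is a limit and not a number. Compound 1 `CCc1ccc(S(=O)(=O)NCCC[C@H]2C(=O)N(c3ccc(C)cc3)[C@@H]2c2ccc([N+](=O)[O-])cc2)cc1` gives > 100000 nM, which is also a limit. Between them lies a step that the two limits leave unreadable from compound 1 to compound 2. Compound 2 therefore stands on (the limit of > 100000 nM in this assay, at which 2 of the 3 values shown sit).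

Compound 4 `Cc1ccc(N2C(=O)[C@H](CCCNS(=O)(=O)c3ccc(OC(F)(F)F)cc3)[C@H]2c2ccc(NS(C)(=O)=O)cc2)cc1` differs from compound 2 in one place: methanesulfonamido in place of nitro on an aromatic carbon. The closest guide is compound 3 `CCc1ccc(S(=O)(=O)NCCC[C@H]2C(=O)N(c3ccc(C)cc3)[C@@H]2c2ccc(NS(=O)(=O)c3ccc(C)cc3)cc2)cc1`, which carries ((4-methylphenyl)sulfonyl)amino where compound 1 has nitro. In this assay compound 3 gives 42900 nM, a real number. That swap produced an at least 2.3-fold lower number from compound 1 to compound 3 (0.36 log units; beyond the scatter). The guide is only loose, since the entering group differs and compound 3 keeps the ethyl group rather than trifluoromethoxy.

A modest fall in this assay is therefore expected, towards less compound tolerated, though a result still at the limit is quite possible. The expected step is an at least 1.6-fold lower number from compound 2 to compound 4 (0.22 log units; that floor lies within the scatter). Compound 4 is estimated at 60000 nM, with an expected range from 25000 nM to 100000 nM.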

Compound 4, concentration lethal to 50% of the cells in the HEK293 assay: > 100000 nM
Compound 4 was reported as a limit (the forecaster's own chance of this, stated with the estimate: 40%); middle value at least 1.6-fold (0.22 log units) away from the limit.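

In the HEK293 assay compound 2 gives > 100000 nM, which is a limit and not a number. In the HEK293 assay compound 4 gives > 100000 nM, which is also a limit, and the step between the two compounds cannot be read. The compounds shown leave open how much of either compound cells tolerate beyond that limit, and whether methanesulfonamido in place of nitro changes that tolerance at all. In a physicochemical assay for lipophilicity, read by HPLC, measured as octanol-water partition (on this read-out higher numbers stand for higher lipophilicity and lower numbers for lower lipophilicity), compound 2 gives >= 4.4, which is a limit and not a number. In the physicochemical assay compound 4 gives 3.4.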